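Furan-to-thiophene swap at the dienone terminus

The compounds below may be only part of what the source reports. "The series", "measured", "known", "first", "only" and "open" are said of these compounds alone.

Compound 1 `COc1ccccc1/C=C/C(=O)/C=C/c1ccc(OCc2cn(CCCOc3cc(=O)oc4ccccc34)nn2)c(OC)c1`, compound 2 `COc1cc(/C=C/C(=O)/C=C/c2cc(OC)c(OC)c(OC)c2)ccc1OCc1cn(CCCOc2cc(=O)oc3ccccc23)nn1` and compound 3 `COc1cc(/C=C/C(=O)/C=C/c2ccco2)ccc1OCc1cn(CCCOc2cc(=O)oc3ccccc23)nn1` share one core and differ only in the group on a double-bonded chain carbon bound to a double-bonded chain carbon. In a functional assay on COLO 205 cells (Homo sapiens) for inhibition, read by sulforhodamine B assay, with a stated time of 48 h, tested at 50 uM (a higher number here means more inhibition of growth at the concentration tested, a lower number less inhibition of growth), compound 1 gives 57%, compound 2 gives 74% and compound 3 gives 59%. Compound 3 stands second highest of the three: its nearest neighbour is compound 1, separated by a gap within the scatter, while compound 2 lies further off, beyond the scatter. The measured steps are a number 17 percentage points higher from compound 1 to compound 2 (beyond the scatter), a number 2 percentage points higher from compound 1 to compound 3 (within the scatter) and a number 15 percentage points lower from compound 2 to compound 3 (beyond the scatter).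

Compound 4 `COc1cc(/C=C/C(=O)/C=C/c2cccs2)ccc1OCc1cn(CCCOc2cc(=O)oc3ccccc23)nn1` is the next member. The change from compound 3 is thiophen-2-yl in place of furan-2-yl on a double-bonded chain carbon bound to a double-bonded chain carbon. Among the measured compounds shown here, no measured step swaps one five-membered aromatic ring with 1 hetero atom for another. The steps that touch the furan-2-yl compound are a number 2 percentage points higher from compound 1 to compound 3 (within the scatter), within the scatter, and a number 15 percentage points lower from compound 2 to compound 3 (beyond the scatter), modest, and both bring in 2-methoxyphenyl or 3,4,5-trimethoxyphenyl rather than a close counterpart, so they bound the question only loosely. Given that the entering group repeats the leaving group in ring size, hetero-atom count and acceptor count, the expected step is a number 1 percentage points higher from compound 3 to compound 4 (within the scatter), none beyond the scatter. Compound 4 is therefore estimated at 60% in this assay, with a range from 48% to 72%.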

Compound 4, percent growth inhibition at one concentration: 55%
Compound 4: the middle estimate sits 5 percentage points above what was measured; the measured number falls inside the stated range.
By their numbers in this assay, from the lowest: compounds 4, 1 and 3 (each within the scatter of the next); then compound 2.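

Thiophen-2-yl in place of furan-2-yl on a double-bonded chain carbon bound to a double-bonded chain carbon gives a number 4 percentage points lower from compound 3 to compound 4 (within the scatter) in this assay. Among the compounds shown here, this is the first direct exchange of one five-membered aromatic ring with 1 hetero atom for another at this position, and exchanging the ring oxygen for sulfur gives no resolved change in this read-out. For the compounds shown here, with a number 2 percentage points lower from compound 1 to compound 4 (within the scatter) as well, 2-methoxyphenyl, furan-2-yl and thiophen-2-yl now all lie within the scatter of one another, whereas a number 19 percentage points lower from compound 2 to compound 4 (beyond the scatter) leaves compound 2, with its 3,4,5-trimethoxyphenyl group, as the only member beyond the scatter of every other compound and the highest of the four.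

Nothing available here bears on why these groups read as they do. Still open, from the compounds shown here alone, is how a pyridin-3-yl ring or a phenyl ring carrying a carboxylic acid would read at this position, and whether the gap to compound 2 follows the number of methoxy groups or belongs to the 3,4,5-trimethoxyphenyl group as a whole.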